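Fluorinated phenyl in place of pyridin-3-yl on compound 3

The source may report more compounds than this note shows. Statements on the series, on what has been measured and on what is new or still open speak of the compounds shown alone.

In a functional assay on KG-1a cells (Homo sapiens) for inhibition, read by MTT assay, with a stated time of 72 h (on this read-out lower numbers stand for stronger inhibition and higher numbers for weaker inhibition), three compounds have been measured:
compound 1, `Cc1ccc(-c2cn(-c3ccc(CN4CCN(C)CC4)c(C(F)(F)F)c3)nn2)cc1Nc1nccc(-c2cccnc2)n1`: 1040 nM
compound 2, `Cc1ccc(-c2nnc(-c3ccc(C)c(C(F)(F)F)c3)o2)cc1Nc1nccc(-c2cccnc2)n1`: > 30000 nM
compound 3, `Cc1ccc(-c2nnc(-c3cccnc3)o2)cc1Nc1nccc(-c2cccnc2)n1`: > 30000 nM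

The value given for compound 3 is a limit of the assay, not a number. The value given for compound 2 is likewise a limit. Two of the three values therefore sit at the limit of > 30000 nM in this assay, at which 2 of the 3 values shown sit, and only compound 1 yields a number. The step that the two limits leave unreadable from compound 2 to compound 3 is accordingly unreadable.

Compound 4, `Cc1ccc(-c2nnc(-c3ccc(F)c(C(F)(F)F)c3)o2)cc1Nc1nccc(-c2cccnc2)n1`, arises from compound 3 through (4-fluoro-3-(trifluoromethyl)phenyl in place of pyridin-3-yl on an aromatic carbon). Among the measured compounds shown here, the only measured step that bears on this position is the one from compound 2 to compound 3, which runs the other way and cannot be sized. Compound 2, which carries 4-methyl-3-(trifluoromethyl)phenyl at the same place, gives only a limit, as does compound 3.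

Compound 4 is therefore expected once more at the limit, estimated at 30000 nM with a range from 10000 nM to 80000 nM. The expected step from compound 3 to compound 4, a number no higher from compound 3 to compound 4 (the limit leaves the size open), is expected to show no readable change.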

Compound 4, half-maximal inhibitory concentration: > 30000 nM
Compound 4: a limit, no number (the forecaster's own chance of this, stated with the estimate: 80%); the middle value sits exactly at the limit.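

In this assay, among the compounds shown here, compound 4 gives > 30000 nM, a limit and not a number, and no step among compound 2, compound 3 and compound 4 can be read. The compounds shown leave open whether the group changed at this place affects inhibition at all.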